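The compounds below may be only part of what the source reports. "The series", "measured", "known", "first", "only" and "open" are said of these compounds alone.

Compound 1, `CC(C)n1ncc2c(C(=O)Nc3cccnc3)cccc21`, in a functional assay on PC-3 cells (Homo sapiens) for inhibition, read by MTT assay, with a stated time of 72 h (a higher number here means a weaker inhibitor, a lower number a stronger inhibitor), gives > 40000 nM, which is a limit of the assay and not a number. Compound 2, `CC(C)n1ncc2c(C(=O)NC3CCCC3)cccc21`, in this assay gives 19400 nM. Compound 3, `CC(C)n1ncc2c(C(=O)NCc3cn(-c4cccc(Br)c4)nn3)cccc21`, in this assay gives 33700 nM.

Compound 3 thus has the highest of the two numbers reported; the nearest is compound 2, whose figure is lower by an amount that stays within the scatter. Among the compounds with values here, the one measured step, an at least 2.0-fold lower number from compound 1 to compound 2 (0.31 log units; beyond the scatter), concerns the group on the amide nitrogen and not the triazole, and it starts from a limit, (the limit of > 40000 nM in this assay, at which 1 of the 3 values shown sits), so it bounds the step only from one side.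

Compound 4, `CC(C)n1ncc2c(C(=O)NCc3cn(-c4ccc(C(F)(F)F)cc4)nn3)cccc21`, differs from compound 3 in one place: 4-(trifluoromethyl)phenyl in place of 3-bromophenyl on an aromatic nitrogen. Within the data shown here, no measured step touches this position, and the two changes of the aryl group on the triazole nitrogen are of similar size and shape. The change is therefore expected to leave the number where compound 3 stands, with a step of a 1.1-fold lower number from compound 3 to compound 4 (0.05 log units; within the scatter) that is expected to lie within the scatter. Compound 4 is estimated to give about 30000 nM in this assay, within a range from 12000 nM to 70000 nM.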

Compound 4, half-maximal inhibitory concentration: 38600 nM
The estimate for compound 4 lay 1.3-fold (0.11 log units) below the measured number; the measured number falls inside the stated range.
By their numbers in this assay, from the lowest: compounds 2, 3 and 4 (each within the scatter of the next). At a limit, above all of these: compound 1.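

Within the data shown here, the step at this position, a 1.1-fold higher number from compound 3 to compound 4 (0.06 log units; within the scatter) in this assay, is the first measured one on the aromatic nitrogen of the five-membered aromatic ring, since the only earlier step concerned the group on the amide nitrogen. It shows that 4-(trifluoromethyl)phenyl, with 10 heavy atoms, and 3-bromophenyl, with 7, cannot be told apart in this read-out, even though the substituent and its place on the six-membered ring both differ, and this single pair cannot separate those two differences. None of the information given here bears on why the two numbers stand so close.

What the compounds shown leave open is whether a group of another kind on this aromatic nitrogen, such as a phenyl ring carrying an amine or a carboxylic acid, or a longer alkyl chain in place of the phenyl ring, would give a number beyond the scatter from that of compound 3. Also open, on these data alone, is whether 4-bromophenyl or 3-(trifluoromethyl)phenyl would read like the two aryl groups already in hand.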